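The source may hold more compounds than are shown below. What is called first, only, known or untested is meant among the compounds shown, and "the series" means these compounds.

Measured so far:
- compound 1 `Nc1nc2ccc(C(=O)C(F)(F)F)cc2s1` — in a functional assay on the whole organism with Rattus norvegicus as the target (a higher number here means that more compound is needed for the effect, a lower number that less compound is needed), compound 1 gives > 10 mg/kg, which is a limit of the assay and not a number.
- compound 2 `CCN(CC)C(=O)Cn1c(=N)sc2cc(OC(F)(F)F)ccc21` — in this assay compound 2 gives 9 mg/kg.

Among the compounds with values here, compound 2 thus stands as the only actual number in this assay; the other entry is a limit (the limit of > 10 mg/kg in this assay, at which 1 of the 2 values shown sits). Within the data shown here, no step between two measured compounds is available, so the size of a change cannot be read from the series itself.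

Compound 3 `CN(C)CCCn1c(=N)sc2cc(OC(F)(F)F)ccc21` is not yet measured. It differs from compound 2 as follows: 2-(dimethylamino)ethyl in place of diethylcarbamoyl on a saturated chain carbon bound to an aromatic nitrogen. With nothing measured on this kind of change, the step in this assay is expected to be small, not beyond the usual scatter, and if anything toward a slightly lower dose.

For compound 3 the expected result in this assay is 7 mg/kg, with a range from 3 mg/kg to 20 mg/kg, corresponding to an expected step of a 1.3-fold lower number from compound 2 to compound 3 (0.11 log units; within the scatter).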

Compound 3, dose for half-maximal effect: 9 mg/kg
Estimate against measurement, compound 3: 1.3-fold (0.11 log units) below, and the stated range covers the measured number.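

Within the data shown here, replacing diethylcarbamoyl with 2-(dimethylamino)ethyl on a saturated chain carbon bound to an aromatic nitrogen gives the first readable step in this assay: no change at the digits printed from compound 2 to compound 3 (within the scatter). At this place, the carbonyl of diethylcarbamoyl is therefore not needed to keep the dose where it stands, and a chain ending in a dimethylamino group serves equally well. This rests on a single pair, so it shows that the position accepts this one exchange, not that it accepts changes in general.

On these data alone, whether a longer chain, a carboxylic acid or a morpholine at the end of the chain would hold the dose remains open. The entry for compound 1 is a limit and not a number, so it offers no further reading: the limit of > 10 mg/kg in this assay, at which 1 of the 3 values shown sits.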